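A few compounds are considered here, and "the series" means these few. Any claim that something is new, unique, unknown or untested is made for them only; others in the source may bear on it.

Working notes on the series. Compound 1 `O=C(/C=C/c1ccc(OCCCCO[N+](=O)[O-])c(O)c1)OCCCCO[N+](=O)[O-]` carries a hydroxy group on the aromatic ring; compound 3 `COc1cc(/C=C/C(=O)OCCCCO[N+](=O)[O-])ccc1OCCCCO[N+](=O)[O-]` has the same difference as methyl in place of hydrogen on an oxygen on an aromatic ring. In a functional assay on M4E cells (Homo sapiens) for cytotoxicity, read by resazurin assay, with a stated time of 72 h (a lower number here means a stronger inhibitor, a higher number a weaker inhibitor), compound 1 gives only a limit, > 50000 nM. In this assay compound 3 likewise gives only a limit, > 50000 nM. The step is therefore a step that the two limits leave unreadable from compound 1 to compound 3, a consequence of the limit of > 50000 nM in this assay, at which 3 of the 3 values shown sit. Compound 2 `O=C(/C=C/c1ccc(OCCCCCCO[N+](=O)[O-])c(O)c1)OCCCCCCO[N+](=O)[O-]` is the second core; how it differs from compound 1 is not broken down here. In this assay compound 2 again gives only a limit, > 50000 nM. Compound 4 `COc1cc(/C=C/C(=O)OCCCCCCO[N+](=O)[O-])ccc1OCCCCCCO[N+](=O)[O-]` differs from compound 2 by methyl in place of hydrogen on an oxygen on an aromatic ring, the same kind of change as from compound 1 to compound 3. From compound 2 to compound 4 the step is expected to be a step that the limit leaves unreadable from compound 2 to compound 4, resting on the unreadable step that the two limits leave unreadable from compound 1 to compound 3 and on (the limit of > 50000 nM in this assay, at which 3 of the 3 values shown sit). Compound 4 is estimated at 70000 nM, most likely reported as a limit again.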

Compound 4, half-maximal inhibitory concentration: > 50000 nM
Compound 4: a limit, no number; the forecaster's own chance of this, stated with the estimate: 85%; the middle value lies beyond the limit too.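

Compound 2 and compound 4 both give only limits in this assay, so no new step can be read: the limit of > 50000 nM in this assay, at which 4 of the 4 values shown sit.

The compounds shown leave open what size the hydroxy to methoxy change has, and whether any compound in this series reaches a measurable value.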